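Benzyl change from compound 3 to compound 4

This account rests on a few compounds, and the source may have more. Where it says the series, first, only, none or still open, it means among the compounds named here.

Measured in a functional assay on HCT-116 cells (Homo sapiens) for inhibition, read by CCK-8 assay, with a stated time of 48 h; on this read-out lower numbers stand for stronger inhibition and higher numbers for weaker inhibition:
- compound 1 `COc1cc(N(Cc2ccc(Cl)cc2)C(=O)CSC(=S)N2CCN(C(=O)OC(C)(C)C)CC2)cc(OC)c1OC`: 8490 nM
- compound 2 `COc1cc(NC(=O)CSC(=S)N2CCN(C(=O)OC(C)(C)C)CC2)c(Cc2ccccc2)c(OC)c1OC`: 16000 nM
- compound 3 `COc1cc(N(Cc2ccc(C)cc2)C(=O)CSC(=S)N2CCN(C(=O)OC(C)(C)C)CC2)cc(OC)c1OC`: > 20000 nM (a limit, not a number)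

Compound 3 stands at the limit of > 20000 nM in this assay, at which 1 of the 3 values shown sits. Compound 4 `COc1ccc(CN(C(=O)CSC(=S)N2CCN(C(=O)OC(C)(C)C)CC2)c2cc(OC)c(OC)c(OC)c2)cc1F` carries 3-fluoro-4-methoxyphenyl in place of 4-methylphenyl on a saturated chain carbon bound to an amide-type nitrogen. Within the data shown here, the only measured step on this aryl group, an at least 2.3-fold higher number from compound 1 to compound 3 (0.37 log units; beyond the scatter), comes with methyl in place of chloro on an aromatic carbon, so a change here can move the number beyond the scatter. A modest step of similar size towards lower numbers is therefore expected in this assay, though the limit on compound 3 leaves its exact size open. The expected change is an at least 1.5-fold lower number from compound 3 to compound 4 (0.18 log units; that floor lies within the scatter). Compound 4 is estimated at 13000 nM, with an expected range of 5000 nM to 30000 nM.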

Compound 4, half-maximal inhibitory concentration: 8210 nM
Compound 4: the middle estimate sits 1.6-fold (0.20 log units) above what was measured, and the stated range covers the measured number.
By their numbers in this assay, from the lowest: compounds 4, 1 and 2 (each within the scatter of the next). At a limit, above all of these: compound 3.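

In this assay, among these compounds, 3-fluoro-4-methoxyphenyl on this saturated chain carbon gives an at least 2.4-fold lower number from compound 3 to compound 4 (0.38 log units; beyond the scatter), the first step on this aryl group towards lower numbers. Compound 3 remains a limit, so that step has only a floor: the limit of > 20000 nM in this assay, at which 1 of the 4 values shown sits. Against 4-chlorophenyl the change gives a 1.0-fold lower number from compound 1 to compound 4 (0.01 log units; within the scatter), so these two aryl groups cannot be told apart here, while 4-methylphenyl stays apart from both.

Going by these compounds, whether the fluoro or the methoxy group carries the step stays open. So does the effect of an amine or a carboxylic acid on this aryl ring.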